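A few compounds are considered here, and "the series" means these few. Any claim that something is new, unique, unknown or untested is made for them only; others in the source may bear on it.

Three compounds sharing one core have been examined in an assay on CHO cells for displacement of a labelled ligand from adenosine receptor A3 (Homo sapiens), read by scintillation counting, with a stated time of 45 min, in the presence of a further agent that is not named here; a higher number here means a weaker inhibitor, a lower number a stronger inhibitor. Compound 1 `CCCn1c(=O)[nH]c2nc(-c3ccc(S(=O)(=O)N4CCN(c5ccc(Cl)cc5F)CC4)cc3)[nH]c2c1=O` carries a 4-chloro-2-fluorophenyl on an amine nitrogen in a ring; in this assay compound 1 reaches only the limit of the measurement, > 1000 nM. Compound 2 `CCCn1c(=O)[nH]c2nc(-c3ccc(S(=O)(=O)N4CCN(c5ccc(Br)cc5)CC4)cc3)[nH]c2c1=O`, with a 4-bromophenyl in that place, also gives only a limit in this assay, > 1000 nM. Compound 3 `CCCn1c(=O)[nH]c2nc(-c3ccc(S(=O)(=O)N4CCN(c5ccccc5Br)CC4)cc3)[nH]c2c1=O`, with a 2-bromophenyl, likewise stops at a limit in this assay, > 1000 nM. Because all three sit at the limit of > 1000 nM in this assay, at which 3 of the 3 values shown sit, none of the steps among them can be read: a step that the two limits leave unreadable from compound 1 to compound 2, a step that the two limits leave unreadable from compound 1 to compound 3 and a step that the two limits leave unreadable from compound 2 to compound 3 all remain of unknown size. Compound 3 thus stands where compound 1 and compound 2 stand, at the same limit, with no number of its own.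

Compound 4 `CCCn1c(=O)[nH]c2nc(-c3ccc(S(=O)(=O)N4CCN(c5cccc(F)c5)CC4)cc3)[nH]c2c1=O` differs from compound 3 by 3-fluorophenyl in place of 2-bromophenyl on an amine nitrogen in a ring. Among the measured compounds shown here, no measured step bears on this change in a readable way, since every step among the three measured compounds was left unreadable by the limits. The expected step from compound 3 to compound 4 is therefore small or absent, a step that the limit leaves unreadable from compound 3 to compound 4. Compound 4 is expected to give about 3000 nM in this assay, within a range from 800 nM to 30000 nM, and most probably once more only a limit.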

Compound 4, inhibition constant: > 1000 nM
Compound 4: only a limit was reported; the forecaster's own chance of this, stated with the estimate: 85%; the middle value lies beyond the limit too.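

In this assay compound 4 gives only a limit, > 1000 nM. Among the compounds shown here, no step from compound 1, compound 2 or compound 3 to compound 4 can be read, because all four compounds stop at the same point: the limit of > 1000 nM in this assay, at which 4 of the 4 values shown sit. The compounds shown leave open how strongly any of them binds, and whether changing the aryl group on the amine nitrogen in the ring alters that at all.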